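A Methylsulfonyl Amide Among Inactive Analogues

The compounds below may be only part of what the source reports. "The series", "measured", "known", "first", "only" and "open" are said of these compounds alone.

In a functional assay on AN3-CA cells (Homo sapiens) for antiproliferative activity, read by MTT assay, with a stated time of 72 h (on this read-out higher numbers stand for weaker inhibition and lower numbers for stronger inhibition), compound 1 `O=C(Nc1ccc(Cl)c(-c2nnc3c(Cl)cccn23)c1)c1ccc(F)cc1Cl` reaches only the limit of the measurement, giving > 100000 nM. Its two measured companions share the same core. Compound 2 `O=C(Nc1ccc(Cl)c(-c2nnc3c(Cl)cccn23)c1)c1ccccn1` likewise gives only a limit, > 100000 nM. Compound 3 `CS(=O)(=O)c1ccc(C(=O)Nc2ccc(Cl)c(-c3nnc4c(Cl)cccn34)c2)cc1` also stops at a limit, with > 100000 nM. The steps between them are therefore not readable: a step that the two limits leave unreadable from compound 1 to compound 2, a step that the two limits leave unreadable from compound 1 to compound 3 and a step that the two limits leave unreadable from compound 2 to compound 3. Because (the limit of > 100000 nM in this assay, at which 3 of the 3 values shown sit), nothing among these three values shows any change that can be sized.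

Compound 4 `CS(=O)(=O)c1cccc(C(=O)Nc2ccc(Cl)c(-c3nnc4c(Cl)cccn34)c2)c1` has not yet been measured. It differs from compound 1 in one place: 3-(methylsulfonyl)phenyl in place of 2-chloro-4-fluorophenyl on a carbonyl carbon. Among the measured compounds shown here, the step that bears most nearly on this change is the one leading to compound 3, which carries a 4-(methylsulfonyl)phenyl and still sits at the limit. For the measured compounds named here, no measured step on this core has given a readable number, so compound 4 is expected to sit at the limit as well, and the step that the limit leaves unreadable from compound 1 to compound 4 is estimated to show no change beyond the scatter. For compound 4 the estimated value is 150000 nM, expected to fall between 40000 nM and 600000 nM.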

Compound 4, half-maximal inhibitory concentration: > 100000 nM
Compound 4 was reported as a limit; the forecaster's own chance of this, stated with the estimate: 80%; the middle value is on the limit's open side.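

Compound 4 also stops at a limit in this assay, so its steps from compound 1, compound 2 and compound 3 cannot be read: the limit of > 100000 nM in this assay, at which 4 of the 4 values shown sit.

The compounds shown leave open whether any group on this carbonyl carbon gives a readable number on the shared core, and whether 3-(methylsulfonyl)phenyl and 4-(methylsulfonyl)phenyl differ at all.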